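Swapping carbamoyl for carboxy at the assay limit

The source may hold more compounds than are shown below. What is called first, only, known or untested is meant among the compounds shown, and "the series" means these compounds.

For the measured compounds named here, compound 1 `COC(=O)c1ccc(C/C=C(\C)CCC(=O)O)[nH]1` and compound 2 `C/C(=C\Cn1cnc(C(N)=O)n1)CCC(=O)O` are the only compounds tested so far. Compound 1 reads > 100000 nM in a functional assay on PSN1 cells (Homo sapiens) for antiproliferative activity (on this read-out lower numbers stand for stronger inhibition and higher numbers for weaker inhibition), and that reading is a limit of the assay, not a number. Compound 2 reads > 100000 nM in this assay and that reading is also a limit, not a number. Together they give the limit of > 100000 nM in this assay, at which 2 of the 2 values shown sit, and nothing finer.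

Compound 3 `C/C(=C\Cn1cnc(C(=O)O)n1)CCC(=O)O` is still to be measured. It differs from compound 2 in one place (hydroxy in place of amino on a carbonyl carbon): hydroxy in place of amino on a carbonyl carbon, which reads as carbamoyl to carboxy. Going by the values given here, no measured pair shows what this swap does in this assay so the size of the step can only be judged from the two limits. The expectation is no step beyond the scatter, in either direction. That expectation rests on compound 2 and its limit > 100000 nM alone. The estimated outcome is a number no higher from compound 2 to compound 3 (the limit leaves the size open) in this assay and no more. Compound 3 is expected to read about 100000 nM with an estimated range of 50000 nM to 200000 nM and will most likely be reported as a limit again.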

Compound 3, half-maximal inhibitory concentration: > 100000 nM
Compound 3 gave a limit, no number; the forecaster's own chance of this, stated with the estimate: 90%; the middle value sits exactly at the limit.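

For the compounds shown here, compound 2 and compound 3 both stop at a limit in this assay, so the swap from carbamoyl to carboxy gives no step that can be read, and the compounds share one reading: the limit of > 100000 nM in this assay, at which 3 of the 3 values shown sit. The compounds shown leave open what size of effect this swap has, and which structures would give a measurable number in this assay.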